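Substituting the amide nitrogen of compound 3

The compounds below may be only part of what the source reports. "The series", "measured", "known", "first", "only" and "open" are said of these compounds alone.

Measured so far in a physicochemical assay for solubility, read by HPLC, in phosphate buffer, with a stated time of 20 h, at pH 7.4 (a higher number here means a more soluble compound, a lower number a less soluble compound), are three compounds
- compound 1 `O=C(Nc1nnc(Cc2ccccc2)s1)c1ccc(O[C@H]2CC[C@@H](C(=O)O)CC2)nc1` with 89000 nM as its reading
- compound 2 `O=C(Nc1nnc(NC2CCCC2)s1)c1ccc(O[C@H]2CC[C@@H](C(=O)O)CC2)cc1` with 26000 nM as its reading
- compound 3 `NC(=O)C[C@H]1CC[C@H](c2ccc(C(=O)Nc3nnc(Cc4ccccc4)s3)cc2)CC1` with < 2000 nM as its reading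

Compound 3 stands at < 2000 nM in this assay and this is a limit of the assay, not a number. Compound 4 `CN(C)CCNC(=O)C[C@H]1CC[C@H](c2ccc(C(=O)Nc3nnc(Cc4ccccc4)s3)cc2)CC1` has not yet been measured. It carries 2-(dimethylamino)ethyl in place of hydrogen on an amide-type nitrogen of compound 3 2-(dimethylamino)ethyl in place of hydrogen on an amide-type nitrogen and is otherwise unchanged.

Going by the values given here, no measured pair in this set isolates that change, so any step remains an expectation. Compound 1 at 89000 nM and compound 2 at 26000 nM show only how high readings run here, and both differ from compound 3 in more than one place. The expected step is upward and beyond the scatter, estimated as an at least 7.5-fold higher number from compound 3 to compound 4 (0.87 log units; beyond the scatter) in this set. In this assay the estimate for compound 4 is 15000 nM within an expected range of 3000 nM to 70000 nM as its likely reading.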

Compound 4, solubility: < 2000 nM
Compound 4: a limit, no number; the forecaster's own chance of this, stated with the estimate: 15%; at least 7.5-fold (0.87 log units) between middle value and limit.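

In this assay compound 4 gives < 2000 nM as a limit of the assay and not a number. Going by these compounds alone, no step from compound 3 to compound 4 can be read, because both compounds stop at the same limit: the limit of < 2000 nM in this assay, at which 2 of the 4 values shown sit. From the compounds shown here alone, whether the two compounds differ beneath that limit stays open.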